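The compounds below may be only part of what the source reports. "The series", "measured", "known", "first", "only" and "open" are said of these compounds alone.

Measured in an ADME assay on HEK293 cells (Homo sapiens) for cytotoxicity, read by resazurin assay, with a stated time of 48 h; on this read-out lower numbers stand for higher toxicity in this test and higher numbers for lower toxicity in this test:
- compound 1 `Cc1ccc(S(=O)(=O)Nc2ccc(-c3nc4ccccc4o3)cc2)cc1`: 88000 nM
- compound 2 `O=S(=O)(Nc1ccc(-c2nc3ccccc3o2)cc1)c1ccccc1Cl`: > 100000 nM, a limit
- compound 3 `O=S(=O)(Nc1ccc(-c2nc3ccccc3o2)cc1)c1ccc(O)cc1`: > 100000 nM, a limit

Compound 2 has no exact number, only (the limit of > 100000 nM in this assay, at which 2 of the 3 values shown sit). Compound 4 `O=S(=O)(Nc1ccc(-c2nc3ccccc3o2)cc1)c1ccccc1C(F)(F)F` is still unmeasured and differs from compound 2 by trifluoromethyl in place of chloro on an aromatic carbon, which is trifluoromethyl in place of chloro on an aromatic carbon. Among the measured compounds shown here, no measured step makes this exact exchange. The nearest evidence is an at least 1.1-fold higher number from compound 1 to compound 2 (0.05 log units; that floor lies within the scatter), together with an at least 1.1-fold higher number from compound 1 to compound 3 (0.05 log units; that floor lies within the scatter). Neither shows a change beyond the scatter, and a step that the two limits leave unreadable from compound 2 to compound 3 adds no size. The expected result is a number no higher from compound 2 to compound 4 (the limit leaves the size open), meaning no step beyond the scatter in this assay. For compound 4 the estimate is 100000 nM, with an expected range from 50000 nM to 200000 nM.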

Compound 4, half-maximal cytotoxic concentration: > 100000 nM
Compound 4: a limit, no number; the forecaster's own chance of this, stated with the estimate: 70%; the middle value sits exactly at the limit.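

Compound 2 and compound 4 each give only a limit, so no step between them can be read: the limit of > 100000 nM in this assay, at which 3 of the 4 values shown sit.

Going by these compounds, whether trifluoromethyl in place of chloro shifts the result in this assay at all stays open.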